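The compounds below may be only part of what the source reports. "The series", "measured", "known", "first", "only" and "open" are said of these compounds alone.

Measured so far in a functional assay on HCC827 cells (Homo sapiens) for antiproliferative activity, read by MTT assay, with a stated time of 72 h; on this read-out lower numbers stand for stronger inhibition and higher numbers for weaker inhibition:

Compound 1 `CN1CCN(c2ccc(Nc3ncc4nc(Nc5ccc(F)cc5)n(-c5cccc(NC(=O)CO)c5)c4n3)cc2)CC1`: 7.5 nM
Compound 2 `CN1CCN(c2ccc(Nc3ncc4nc(Nc5ccccc5)n([C@H]5CCN(S(C)(=O)=O)C5)c4n3)cc2)CC1`: 17 nM
Compound 3 `CC(=O)N1CC[C@H](n2c(Nc3ccccc3)nc3cnc(Nc4ccc(N5CCN(C)CC5)cc4)nc32)C1`: 260 nM

Compound 1 gives the lowest number of the three. Compound 2 stands nearest, beyond the scatter, and compound 3 stands furthest. For the measured compounds named here, the one step that can be read within the measured set, a 15-fold higher number from compound 2 to compound 3 (1.18 log units; beyond the scatter), concerns the group on the ring amine nitrogen of the saturated ring borne by the core, not the side chain altered here.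

Compound 4 `CC(=O)Nc1cccc(-n2c(Nc3ccc(F)cc3)nc3cnc(Nc4ccc(N5CCN(C)CC5)cc4)nc32)c1` differs from compound 1 by hydrogen in place of hydroxy on a saturated chain carbon bound to a carbonyl carbon. Going by the values given here, no measured pair shows this change, and the step between compound 2 and compound 3 does not bear on it. With the amide retained and the rest of compound 1 unchanged, a step within the scatter is expected; the estimate is a 1.3-fold higher number from compound 1 to compound 4 (0.12 log units; within the scatter). Compound 4 is expected at 10 nM, in the range 4 nM to 30 nM.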

Compound 4, half-maximal inhibitory concentration: 10 nM
Compound 4: the middle estimate sits on the measured number at the digits printed; low and high end bracket the measured number.
By their numbers in this assay, from the lowest: compounds 1, 4 and 2 (each within the scatter of the next, the first and the last beyond it); then compound 3.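

In this assay, replacing hydroxy with hydrogen on a saturated chain carbon bound to a carbonyl carbon gives a 1.3-fold higher number from compound 1 to compound 4 (0.12 log units; within the scatter). This first measured pair on this side chain shows that the numbers for ((hydroxymethyl)carbonyl)amino and acetamido cannot be told apart, so on the core of compound 1 the hydroxy group is not needed to keep the number low. No measurement at hand gives a reason for this result.

The compounds shown leave open whether an amine, a carboxylic acid or a longer chain in place of the hydroxymethyl group would also stay within the scatter of compound 1. For the compounds shown here, they also leave open what the amide itself contributes, as no compound here carries a plain amino group in place of acetamido.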